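From 2-bromobenzyl to 3-phenylprop-2-en-1-yl on a shared core

The source may report more compounds than this note shows. Statements on the series, on what has been measured and on what is new or still open speak of the compounds shown alone.

Compound 1 `Cc1cc(=O)c2c(O)cc(OCc3ccc([N+](=O)[O-])cc3)c([C@H]3CCN(C)C[C@H]3O)c2o1` and compound 2 `Cc1cc(=O)c2c(O)cc(OCc3ccccc3Br)c([C@H]3CCN(C)C[C@H]3O)c2o1` share one core and differ in a single group, on a saturated chain carbon bound to an oxygen on an aromatic ring. In a functional assay on MCF7 cells (Homo sapiens) for inhibition, read by MTT assay, with a stated time of 48 h, tested at 10 uM (on this read-out higher numbers stand for more inhibition of growth at the one concentration tested and lower numbers for less inhibition of growth), compound 1 gives 39% and compound 2 gives 45%, so compound 2 stands level with compound 1 within the scatter. Compound 3 `Cc1cc(=O)c2c(O)cc(OC/C=C/c3ccccc3)c([C@H]3CCN(C)C[C@H]3O)c2o1` keeps the core of compound 2 and alters the same place, with 2-phenylethenyl in place of 2-bromophenyl (2-phenylethenyl in place of 2-bromophenyl on a saturated chain carbon bound to an oxygen on an aromatic ring). The entering group keeps a six-membered aromatic ring of carbon only and brings a double bond outside aromatic rings. For the measured compounds named here, only one measured step bears on this change. It sits at the same place, 2-bromophenyl in place of 4-nitrophenyl, and gives a number 6 percentage points higher from compound 1 to compound 2 (within the scatter), so no step beyond the scatter is expected in this assay. Going by the values given here, that is thin evidence, since no measured compound yet carries the double bond. The expected change is a number 2 percentage points lower from compound 2 to compound 3 (within the scatter). For compound 3 the estimate is 43%, with an expected range from 28% to 58%.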

Compound 3, percent growth inhibition at one concentration: 7%
Compound 3: middle estimate off by 36 percentage points, on the high side; measured number below the stated range.
By their numbers in this assay, from the lowest: compound 3; then compounds 1 and 2 (each within the scatter of the next).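

In this assay this position proves far from indifferent to the group it carries: 2-phenylethenyl in place of 2-bromophenyl gives a number 38 percentage points lower from compound 2 to compound 3 (beyond the scatter) and 2-phenylethenyl in place of 4-nitrophenyl gives a number 32 percentage points lower from compound 1 to compound 3 (beyond the scatter) on the same shared core. For the compounds shown here, the earlier pair could not show this, as its one step, a number 6 percentage points higher from compound 1 to compound 2 (within the scatter), stayed within the scatter and gave no sign that a change at this place could matter much. The entering group keeps the six-membered aromatic ring of carbon only and brings a double bond outside aromatic rings, so among these three compounds an aromatic ring in this group is not enough on its own to keep the inhibition of growth seen with compound 1 and compound 2.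

No measurement at hand explains why the number falls so far with this change. From the compounds shown here alone, what stays open is whether the double bond or the different carbon count of the chain accounts for the loss, a question that a saturated 3-phenylpropyl chain on the same oxygen, or a 2-bromophenyl ring carried on a 3-carbon chain with a double bond, could help to separate.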